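The compounds below may be only part of what the source reports. "The series", "measured", "known", "first", "only" and "open" are said of these compounds alone.

Going by the values given here, compound 2 `COc1ccccc1-c1cc(O)c2cccnc2n1` gives 39800 nM in a functional assay on MDA-MB-435 cells (Homo sapiens) (on this read-out higher numbers stand for weaker inhibition of growth and lower numbers for stronger inhibition of growth), the highest of the two numbers measured so far; its nearest neighbour is compound 1 `COc1ccccc1-c1cc(O)c2cc(C)cnc2n1`, which in this assay gives 3020 nM. The change from compound 2 to compound 3 `COc1ccccc1-c1cc(O)c2ccc(C)nc2n1` is methyl in place of hydrogen on an aromatic carbon. Among the compounds with values here, one measured step bears on it: the step of a 13-fold higher number from compound 1 to compound 2 (1.12 log units; beyond the scatter), in which a hydrogen took the place of a methyl on another aromatic carbon of the same core. That step suggests a methyl on this core brings the number down, although the new methyl sits on a different carbon, so the size of the effect is less certain. Compound 3 is therefore expected to show a step of a 5.0-fold lower number from compound 2 to compound 3 (0.70 log units; beyond the scatter) in this assay, towards stronger inhibition. The estimated value for compound 3 is 8000 nM, with a range from 2000 nM to 32000 nM.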

Compound 3, concentration for 50% growth inhibition: 21900 nM
Compound 3: the middle estimate sits 2.7-fold (0.44 log units) below what was measured; measured number inside the range.
By their numbers in this assay, from the lowest: compound 1; then compounds 3 and 2 (each within the scatter of the next).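

In this assay, methyl in place of hydrogen on the aromatic carbon next to the ring nitrogen gives a 1.8-fold lower number from compound 2 to compound 3 (0.26 log units; within the scatter), a step within the scatter, so at this position the methyl does not separate compound 3 from compound 2. The other methyl, lost in a 13-fold higher number from compound 1 to compound 2 (1.12 log units; beyond the scatter), marks a step beyond the scatter, so across these three compounds the read-out depends on which carbon of the shared core carries the methyl. Nothing available explains this difference between the two carbons.

As far as these compounds go, it remains open whether a larger or different group at the position next to the ring nitrogen, such as an ethyl chain, an amine or a carboxylic acid, would move the number beyond the scatter. Going by these compounds alone, it is also open whether a methyl on both carbons together would add anything to the single methyl of compound 1.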